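The source may hold more compounds than are shown below. What is called first, only, known or untested is meant among the compounds shown, and "the series" means these compounds.

Two members of the series have numbers in an ADME assay on PANC-1 cells (Homo sapiens) for inhibition, read by MTT assay; a lower number here means a stronger inhibitor of growth, a higher number a weaker inhibitor of growth. Compound 1, `CCCCCc1cc2c(=O)n(CCCSc3nc(-c4cc(OC)c(OC)c(OC)c4)c(C#N)c(=O)[nH]3)cnc2s1`, gives 72.8 ug/mL in this assay and stands as the higher of the two numbers. Compound 2, `CCCCCCc1cc2c(=O)n(CCSc3nc(-c4cc(OC)c(OC)c(OC)c4)c(C#N)c(=O)[nH]3)cnc2s1`, gives 36.5 ug/mL in this assay; the two values lie within the scatter of each other, so no order between compound 1 and compound 2 can be read from them. Compound 3, `CCCCCCc1cc2c(=O)n(CCCSc3nc(-c4cc(OC)c(OC)c(OC)c4)c(C#N)c(=O)[nH]3)cnc2s1`, has not been measured in this assay. It differs from compound 1 by methyl in place of hydrogen on a saturated chain carbon, five bonds along the chain from an aromatic carbon, the rest of the shared core being kept unchanged. Going by the values given here, no measured pair isolates this change, so nothing in the data fixes its size or direction. The step of a 1.5-fold lower number from compound 1 to compound 3 (0.16 log units; within the scatter) is therefore expected to be small, within the scatter or only a little beyond it, with the direction uncertain. Compound 2 reads 36.5 ug/mL and serves as a loose guide. Compound 3 is expected to give about 50 ug/mL in this assay, with a range from 25 ug/mL to 100 ug/mL.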

Compound 3, concentration for 50% growth inhibition: 28.1 ug/mL
The estimate for compound 3 lay 1.8-fold (0.25 log units) above the measured number, and the stated range covers the measured number.
By their numbers in this assay, from the lowest: compounds 3, 2 and 1 (each within the scatter of the next, the first and the last beyond it).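

In this assay, going by these compounds alone, methyl in place of hydrogen on a saturated chain carbon, five bonds along the chain from an aromatic carbon, gives a 2.6-fold lower number from compound 1 to compound 3 (0.41 log units; beyond the scatter), the first measured step that isolates this change. It fixes the direction at this position as toward a stronger inhibitor of growth, with a modest size that rests on this single pair. Nothing on hand accounts for the step.

On these data alone, with one pair, no trend along the chain can be read, so it remains open whether a longer chain such as heptyl or octyl would carry the number further down or reverse it. Also open, as far as these compounds go, is how the same position responds to a chain ending in an amine or a carboxylic acid.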